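The compounds below may be only part of what the source reports. "The series", "measured", "known", "first", "only" and "open" are said of these compounds alone.

Of the compounds shown here, three built on a shared core have been measured so far in a functional assay on MIA PaCa-2 cells (Homo sapiens) for inhibition, read by MTT assay, with a stated time of 48 h, tested at 10 uM (on this read-out lower numbers stand for less inhibition of growth and higher numbers for more inhibition of growth at the one concentration tested), and give modest values. In this test compound 1 `Cc1cc(=O)c2c(O)cc(OCc3ccccc3Br)c([C@H]3CCN(C)C[C@H]3O)c2o1` gives 30% at the single concentration used, compound 2 `Cc1cc(=O)c2c(O)c(CN3CCCC3)c(O)c([C@H]3CCN(C)C[C@H]3O)c2o1` gives 28% and compound 3 `Cc1cc(=O)c2c(O)c(CN3CCC(Cc4ccccc4)CC3)c(O)c([C@H]3CCN(C)C[C@H]3O)c2o1` gives 18% in the same experiment. Compound 2 lies within the usual scatter of both other compounds, so the data do not separate it from either one.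

Compound 4 `Cc1cc(=O)c2c(O)c(CN3CC(O)CC3C(=O)O)c(O)c([C@H]3CCN(C)C[C@H]3O)c2o1` has not yet been measured. It carries 2-carboxy-4-hydroxypyrrolidin-1-yl in place of pyrrolidin-1-yl on a saturated chain carbon bound to an aromatic carbon, and the full difference reads 2-carboxy-4-hydroxypyrrolidin-1-yl in place of pyrrolidin-1-yl on a saturated chain carbon bound to an aromatic carbon for this exchange.

Among the compounds with values here, no measured pair differs in one place alone, so the size of this step has no direct precedent. The nearest guide is that compound 3 gives 18% and compound 2 gives 28% with different groups on that chain carbon, a gap within the scatter. A small downward move or none beyond the scatter is therefore expected, and the estimated change is a number 8 percentage points lower from compound 2 to compound 4 (within the scatter) in this test. For compound 4 the expected value is 20% with an estimated range from 6% to 34% in this measurement.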

Compound 4, percent growth inhibition at one concentration: 23%
Estimate against measurement, compound 4: 3 percentage points below; low and high end bracket the measured number.
By their numbers in this assay, from the lowest: compounds 3, 4, 2 and 1 (each within the scatter of the next, the first and the last beyond it).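

In this assay, within the data shown here, the exchange of pyrrolidin-1-yl for 2-carboxy-4-hydroxypyrrolidin-1-yl gives a number 5 percentage points lower from compound 2 to compound 4 (within the scatter) and provides the first reading of a change in one place. At this position, on a saturated chain carbon bound to an aromatic carbon, the data therefore do not separate the plain pyrrolidine ring from one carrying both a carboxylic acid and a hydroxyl group, so this larger group leaves the result within the usual spread of the test. No measurement at hand bears on why the two compounds are not separated.

Going by these compounds, the carboxylic acid and the hydroxyl group enter together here, so it remains open what each would do alone on the pyrrolidine ring, and whether a morpholine, a piperazine or an open-chain dimethylamino group at the same place would also stay within the scatter of compound 2. On these data alone, with one concentration tested, it also remains open whether compound 2 and compound 4 would differ at other concentrations.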